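1-Carboxycyclopropyl in place of 1-carboxyethyl

The source may hold more compounds than are shown below. What is called first, only, known or untested is meant among the compounds shown, and "the series" means these compounds.

Measured so far in a physicochemical assay for lipophilicity, at pH 7.4 (a lower number here means a more polar compound, a higher number a more lipophilic compound), are three compounds:
- compound 1 (`COc1ccc(Cl)cc1NC(=O)Cc1nn(CC(=O)O)c(=O)c2ccccc12`) at 1.9
- compound 2 (`C[C@@H](C(=O)O)c1nn(Cc2cn3cc(OCC4CC4)c(Cl)cc3n2)c2ccccc2c1=O`) at 2.41
- compound 3 (`COc1cc(OC)c(NC(=O)Cc2cn(CC(=O)O)c3ccccc23)cc1Cl`) at 2.13

Compound 2 and compound 3 lie within the usual scatter of each other, while compound 1 lies lower than compound 2 by more than that scatter. Compound 4 (`O=C(O)C1(c2nn(Cc3cn4cc(OCC5CC5)c(Cl)cc4n3)c3ccccc3c2=O)CC1`) differs from compound 2 in one place, on an aromatic carbon of a six-membered aromatic ring with 2 nitrogen (1-carboxycyclopropyl in place of 1-carboxyethyl on an aromatic carbon). There, 1-carboxycyclopropyl takes the place of 1-carboxyethyl. Among the measured compounds shown here, no measured pair in this set shows such a change, so the expectation rests only on the structural change and on compound 2 at 2.41 as the starting point. In this assay a small upward step is expected, a number 0.14 log units higher from compound 2 to compound 4 (within the scatter) and it may well stay within the scatter. Compound 4 is expected at 2.55 with 2.2 to 2.9 as its estimated range.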

Compound 4, distribution coefficient: 2.46
Estimate against measurement, compound 4: 0.09 log units above; low and high end bracket the measured number.
By their numbers in this assay, from the lowest: compounds 1, 3, 2 and 4 (each within the scatter of the next, the first and the last beyond it).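

In this assay the exchange of 1-carboxyethyl for 1-carboxycyclopropyl on an aromatic carbon gives a number 0.05 log units higher from compound 2 to compound 4 (within the scatter) and so does not separate the two compounds. This position therefore accepts the three-membered ring of carbon only, with one more heavy atom and without the defined stereocentre, while the number stays within the scatter. Nothing measured here gives a reason for this outcome.

This one pair does not show whether a larger ring, as in 1-carboxycyclobutyl, or a longer chain carrying the carboxylic acid would stay as close at this position. It also leaves open what would follow if a tetrazole or a primary amide took the place of the carboxylic acid.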